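Ethoxy for Methoxy on a Second Core: Tolerability Outlook

The compounds below may be only part of what the source reports. "The series", "measured", "known", "first", "only" and "open" are said of these compounds alone.

Compound 1 `COc1ccccc1-c1nn2cnnc2s1` carries a methoxy group on its phenyl ring, and compound 2 `CCOc1ccccc1-c1nn2cnnc2s1` differs from it by methyl in place of hydrogen on a saturated chain carbon bound to an oxygen on an aromatic ring. Compound 3 `COc1ccccc1-c1nc2ccncc2s1` keeps the methoxy group but is built on a different core; the difference between the two cores is not broken down here. Compound 4 `CCOc1ccccc1-c1nc2ccncc2s1` stands to compound 3 as compound 2 stands to compound 1: methyl in place of hydrogen on a saturated chain carbon bound to an oxygen on an aromatic ring, the same change at the same place.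

In an ADME assay on Vero cells (Chlorocebus sabaeus) for cytotoxicity (a higher number here means that more compound is tolerated, a lower number that less compound is tolerated), compound 1 gives > 80000 nM, which is a limit of the assay rather than a number. Compound 2 likewise reaches only a limit, > 65000 nM. Compound 3 too is reported only as a limit, > 50000 nM. The step that the two limits leave unreadable from compound 1 to compound 2 cannot be sized because the limit of > 80000 nM in this assay, at which 1 of the 3 values shown sits, and the limit of > 65000 nM in this assay, at which 1 of the 3 values shown sits, bound the values from one side only. Nothing in these three results separates the compounds from one another in this assay, and the limit of > 50000 nM in this assay, at which 1 of the 3 values shown sits, adds no further resolution.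

For compound 4 the same change is expected to behave as it did from compound 1 to compound 2, so the step that the limit leaves unreadable from compound 3 to compound 4 is expected to be negligible and most likely hidden again behind a limit. Compound 4 is expected to give 60000 nM in this assay, within an estimated range of 30000 nM to 120000 nM. That expectation rests on the unreadable step that the two limits leave unreadable from compound 1 to compound 2 and on the limit recorded for compound 3.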

Compound 4, half-maximal cytotoxic concentration: > 50000 nM
Compound 4: no number, only a limit; the forecaster's own chance of this, stated with the estimate: 80%; the middle value is on the limit's open side.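

In this assay compound 4 gives > 50000 nM, which is a limit of the assay and not a number. Compound 3 is also reported only as a limit, so no step can be read between compound 3 and compound 4: the limit of > 50000 nM in this assay, at which 2 of the 4 values shown sit.

The compounds shown leave open where any of the four actually stands in this assay, and whether methoxy to ethoxy changes the result on either core.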